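This account rests on a few compounds, and the source may have more. Where it says the series, first, only, none or still open, it means among the compounds named here.

Compound 2 `Cc1cc(=O)[nH]c2cc(N3C(=O)CSC3c3ccc([N+](=O)[O-])cc3)ccc12` gives 25.2% in a functional assay on the whole organism (strain albino) for inhibition, with Rattus norvegicus as the target, read by paw edema, with stated times of 1 h and 3 h, at a dose of 100 mg/kg by the oral route; on this read-out lower numbers stand for less inhibition and higher numbers for more inhibition at the one dose given (going by the name of the read-out); of the two numbers measured it is the higher, but the gap to compound 1 `COc1ccc(C2SCC(=O)N2c2ccc3c(C)cc(=O)[nH]c3c2)cc1`, which gives 21.4%, lies within the scatter, so the two are not truly told apart. Compound 3 `Cc1cc(=O)[nH]c2cc(N3C(=O)CSC3c3ccc(N(C)C)cc3)ccc12` differs from compound 2 in one place: dimethylamino in place of nitro on an aromatic carbon. Among the compounds with values here, the only measured step, a number 3.8 percentage points higher from compound 1 to compound 2 (within the scatter), also exchanged one group on an aromatic carbon for another and stayed within the scatter, so no step beyond the scatter is expected here either. Compound 3 is therefore estimated to give 23%, between 12% and 34%. The expected step is a number 2.2 percentage points lower from compound 2 to compound 3 (within the scatter), within the scatter.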

Compound 3, a percentage reported as inhibition, in the whole organism at one dose (the size of the read-out at that dose, not a potency): 13.3%
Beside the measured number, compound 3's estimate is 9.7 percentage points above it; measured number inside the range.
By their numbers in this assay, from the lowest: compounds 3, 1 and 2 (each within the scatter of the next, the first and the last beyond it).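

In this assay, this position on the aromatic ring now gives a change beyond the scatter: with dimethylamino in place of nitro, the result is a number 11.9 percentage points lower from compound 2 to compound 3 (beyond the scatter). With dimethylamino in place of methoxy, the result is a number 8.1 percentage points lower from compound 1 to compound 3 (within the scatter), so only compound 2 and compound 3 are truly told apart. Nothing available explains this step. Still open, on these data alone, is how a primary amine, a carboxylic acid or a chlorine atom at this position would read, and whether any group would rise clearly above compound 2.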